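A few compounds are considered here, and "the series" means these few. Any claim that something is new, unique, unknown or untested is made for them only; others in the source may bear on it.

Working notes on the series. The shared core carries a methylpiperazine and an arylamino group, and only the arylamino part varies across the four compounds. Compound 1 `Cc1n[nH]c2ccc(-c3nc4cnc(N5CCN(C)CC5)cn4c3Nc3ccccc3F)cc12` bears a 2-fluorophenyl on that nitrogen; in a functional assay on CWR22R cells (Homo sapiens) for inhibition, with a stated time of 120 h, tested at 10 uM (a higher number here means more inhibition at the concentration tested (going by the name of the read-out), a lower number less inhibition), compound 1 gives 0%, so at the concentration tested no inhibition is seen. Compound 2 `Cc1n[nH]c2ccc(-c3nc4cnc(N5CCN(C)CC5)cn4c3Nc3ccc(F)cc3)cc12` carries the 4-fluorophenyl; in this assay compound 2 is recorded as "not determined" (no result reported), so no result is reported for it. Compound 3 `Cc1n[nH]c2ccc(-c3nc4cnc(N5CCN(C)CC5)cn4c3Nc3ccccc3Cl)cc12` carries the 2-chlorophenyl; in this assay compound 3 is likewise recorded as "not determined" (no result reported), so it stands without a single number, alongside one further compound without one.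

The step taken is from compound 3 to compound 4 `Cc1n[nH]c2ccc(-c3nc4cnc(N5CCN(C)CC5)cn4c3Nc3ccc(Cl)cc3)cc12`: 4-chlorophenyl in place of 2-chlorophenyl on a nitrogen on an aromatic ring. With compound 3 unmeasured, no step in this assay can be given a size; on the one number shown, compound 1 at 0%, nothing beyond the scatter is expected in this assay for this change. Compound 4 is expected to give about 8% in this assay, estimated between 0% and 30%.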

Compound 4, a percentage reported as inhibition, at one concentration (the size of the read-out at that concentration, not a potency): 8.11%
For compound 4 the middle estimate is 0.1 percentage points below the measured one; the range from low to high includes it.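

In this assay, replacing 2-fluorophenyl with 4-chlorophenyl on this nitrogen gives a number 8.1 percentage points higher from compound 1 to compound 4 (within the scatter). This swap changes both the halogen and the name of the aryl group, yet the printed step gives no sign of a real difference between the two compounds at the concentration tested. No supporting data bear on this result.

The steps that involve compound 2 or compound 3 cannot be read, so the 2-chlorophenyl to 4-chlorophenyl change and the 2-fluorophenyl to 4-fluorophenyl change each remain without a size. Also open, from the compounds shown here alone, is whether a methoxy group or a carboxylic acid on the phenyl ring, or a cyclohexyl group in place of the phenyl ring, would give a different reading.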